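Triazole-linked diterpenoid analogs: a swap tested on two cores

The compounds below may be only part of what the source reports. "The series", "measured", "known", "first", "only" and "open" are said of these compounds alone.

Compound 1 `Cc1c(O)ccc2c1[C@H](Cn1cc(-c3ccccn3)nn1)[C@@]13CC(=O)[C@@](C)(CC[C@@H]21)C3` carries a pyridin-2-yl group on its triazole. In a functional assay on HL-60 cells (Homo sapiens) for cytotoxicity, read by MTT assay, with a stated time of 4 days (a lower number here means a stronger inhibitor, a higher number a weaker inhibitor), compound 1 gives only a limit of the assay, > 20000 nM. Compound 2 `Cc1c(O)ccc2c1[C@H](Cn1cc(-c3ccc(C(F)(F)F)cc3)nn1)[C@@]13CC(=O)[C@@](C)(CC[C@@H]21)C3` differs from compound 1 by 4-(trifluoromethyl)phenyl in place of pyridin-2-yl on an aromatic carbon. In this assay compound 2 also gives only a limit, > 20000 nM. The resulting step, a step that the two limits leave unreadable from compound 1 to compound 2, cannot be sized from two limits.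

Compound 3 `C=C1C[C@]23C[C@@]1(O)CC[C@H]2c1cc(Br)c(O)c(C)c1[C@@H]3Cn1cc(-c2ccccn2)nn1` sits on a different core, and the difference between the two cores is not broken down here. In this assay compound 3 gives only a limit, > 20000 nM. Among the compounds with values here, the not-yet-measured compound 4 `C=C1C[C@]23C[C@@]1(O)CC[C@H]2c1cc(Br)c(O)c(C)c1[C@@H]3Cn1cc(-c2ccc(C(F)(F)F)cc2)nn1` differs from compound 3 by 4-(trifluoromethyl)phenyl in place of pyridin-2-yl on an aromatic carbon, the same kind of change as the one from compound 1 to compound 2, made at the same kind of place.

For compound 4 the expected step is a step that the limit leaves unreadable from compound 3 to compound 4, resting on (the limit of > 20000 nM in this assay, at which 3 of the 3 values shown sit). Compound 4 is therefore estimated at 25000 nM, within a range of 10000 nM to 60000 nM, most likely reported again as a limit.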

Compound 4, half-maximal inhibitory concentration: 7380 nM
The estimate for compound 4 lay 3.4-fold (0.53 log units) above the measured number; measured number below the stated range.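

In this assay, putting 4-(trifluoromethyl)phenyl in place of pyridin-2-yl gives an at least 2.7-fold lower number from compound 3 to compound 4 (0.43 log units; beyond the scatter), so on the core of compound 3 this change goes with a real gain in strength. On the core of compound 1 the same change cannot be read, as compound 1 and compound 2 both give only limits of the assay, so the data do not show that the gain carries from one core to the other. Even on the core of compound 3, the printed size is only a minimum, because the starting compound rests on a limit rather than on a number: the limit of > 20000 nM in this assay, at which 3 of the 4 values shown sit.

The change swaps two things at once, removing the ring nitrogen and adding the trifluoromethyl group, and the compounds shown do not separate these two parts. As far as these compounds go, it also remains open how a plain phenyl group, or a phenyl group carrying an amine or a carboxylic acid, would behave on the triazole of either core.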